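The source may report more compounds than this note shows. Statements on the series, on what has been measured and on what is new or still open speak of the compounds shown alone.

Of the compounds shown here, two have so far been measured in an ADME assay on microsomes from liver (Rattus norvegicus, strain Sprague-Dawley) for metabolic stability, read by HPLC, using NADPH, with stated times of 5 min and 60 min, tested at 10 uM; a lower number here means slower removal, a higher number faster removal of the compound. Compound 1 `CC(C)S(=O)(=O)Nc1ccc(CNC(=O)c2ccc(C(C)(C)C)cc2)c(Cl)c1` gives 23 mL.min-1.g-1 in this assay. Compound 2 `CN(C)c1ccc(C(=O)NCc2ccc(NS(C)(=O)=O)cc2Cl)cc1` gives 25 mL.min-1.g-1 in this assay. For the measured compounds named here, these two numbers lie within the usual scatter of each other, so no difference between compound 2 and compound 1 can be claimed; on the only two numbers known, compound 2 simply stands alongside compound 1.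

Compound 3 `CC(C)Oc1ccc(C(=O)NCc2ccc(NS(C)(=O)=O)cc2Cl)cc1` has not yet been measured. It differs from compound 2 in a single place: isopropoxy in place of dimethylamino on an aromatic carbon. Going by the values given here, no measured pair shows what such a swap does in this assay, so the expectation rests on the structural change alone and on the two numbers already known. The step is expected to be a 1.1-fold lower number from compound 2 to compound 3 (0.06 log units; within the scatter), which is to say no change beyond the scatter. For compound 3 the estimated value in this assay is 22 mL.min-1.g-1, with a likely range from 10 mL.min-1.g-1 to 45 mL.min-1.g-1.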

Compound 3, intrinsic clearance in microsomes: 12 mL.min-1.g-1
Compound 3: the middle estimate sits 1.8-fold (0.26 log units) above what was measured, and the stated range covers the measured number.
By their numbers in this assay, from the lowest: compounds 3, 1 and 2 (each within the scatter of the next, the first and the last beyond it).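

For the compounds shown here, on an aromatic carbon para to a large group, isopropoxy in place of dimethylamino gives a 2.1-fold lower number from compound 2 to compound 3 (0.32 log units; beyond the scatter) in this assay and so provides the first measured single-place change. It shows that the group at this position can move the number, and that this swap moves it towards slower removal, though the step is modest and only just clears the usual scatter. Nothing shown explains why the number falls.

One swap cannot show whether the lower number is particular to isopropoxy or would also appear with other groups at this position, such as methoxy, a longer alkoxy chain or morpholine. Also open, going by these compounds, is whether the oxygen, the branched carbons or the loss of the nitrogen matters most.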